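Acylthiosemicarbazide series: benzoyl exchange on the unsubstituted core

The source may report more compounds than this note shows. Statements on the series, on what has been measured and on what is new or still open speak of the compounds shown alone.

Working notes on the series. Compound 1 `COc1cc2ncnc(NNC(=S)NC(=O)c3ccc(Cl)cc3)c2cc1OC` gives 4590 nM in a functional assay on KB cells (Homo sapiens) for cytotoxicity, read by MTT assay, with a stated time of 72 h; on this read-out lower numbers stand for stronger inhibition and higher numbers for weaker inhibition. Going by the values given here, compound 3 `COc1cc2ncnc(NNC(=S)NC(=O)c3ccc(C(F)(F)F)cc3)c2cc1OC` gives 8840 nM in this assay, and the step of a 1.9-fold higher number from compound 1 to compound 3 (0.28 log units; within the scatter) is the only single-point comparison measured so far. Compound 2 `COc1ccccc1C(=O)NC(=S)NNc1ncnc2ccccc12` reaches only > 50000 nM in this assay, which is a limit of the assay rather than a number, so compound 2 stands at the weak end of what is shown; the evidence here is the limit of > 50000 nM in this assay, at which 1 of the 3 values shown sits. Compound 4 `O=C(NC(=S)NNc1ncnc2ccccc12)c1cccc(Cl)c1` is not yet measured. It differs from compound 2 by 3-chlorophenyl in place of 2-methoxyphenyl on a carbonyl carbon. Among the compounds with values here, the one measured step, a 1.9-fold higher number from compound 1 to compound 3 (0.28 log units; within the scatter), concerns a different exchange on the aryl group of the acyl part and a different core, so it bears only loosely on the present change; it shows that one substituent exchange there moved nothing beyond the scatter. Compound 1 shows that a chlorophenyl acyl group on a related core yields a number rather than a limit. For compound 4 a number within reach of the assay is expected, with the step of an at least 2.5-fold lower number from compound 2 to compound 4 (0.39 log units; beyond the scatter) toward stronger inhibition. The estimate for compound 4 is 20000 nM, within 5000 nM to 60000 nM.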

Compound 4, half-maximal inhibitory concentration: 4740 nM
Compound 4: the middle estimate sits 4.2-fold (0.63 log units) above what was measured, and the stated range ends above it.
By their numbers in this assay, from the lowest: compounds 1, 4 and 3 (each within the scatter of the next). At a limit, above all of these: compound 2.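

On this carbonyl carbon, 3-chlorophenyl in place of 2-methoxyphenyl gives an at least 10-fold lower number from compound 2 to compound 4 (1.02 log units; beyond the scatter) in this assay. The acyl aryl group can therefore shift this read-out well beyond the scatter on the shared core, which the earlier step, a 1.9-fold higher number from compound 1 to compound 3 (0.28 log units; within the scatter), did not show. The step gives only a bound rather than an exact size, because compound 2 stands at a limit of the assay: the limit of > 50000 nM in this assay, at which 1 of the 4 values shown sits.

The two compounds on this core leave open whether the step follows the entry of 3-chlorophenyl or the departure of 2-methoxyphenyl, since the groups differ in both substituent and name of position. Also open, from the compounds shown here alone, is how an unsubstituted phenyl, or a phenyl carrying an amine or a carboxylic acid, would read on this carbonyl carbon in this assay.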